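The source may report more compounds than this note shows. Statements on the series, on what has been measured and on what is new or still open speak of the compounds shown alone.

Three compounds have so far been measured in a functional assay on BXPC-3 cells (Homo sapiens) for cytotoxicity, read by fluorescence, with a stated time of 48 h; on this read-out higher numbers stand for an effect only at larger amounts of compound and lower numbers for an effect already at smaller amounts:

compound 1, `CC(C)=CCC/C(C)=C/CC/C(C)=C/CSC[C@H](NC(=O)CCCCCN1CCCC1)C(=O)NC1CCCCC1`, giving 12700 nM;
compound 2, `CC(C)=CCC/C(C)=C/CC/C(C)=C/CSC[C@H](NC(=O)CCCCCN1CCCC1)C(=O)NC1CCCC1`, giving 6800 nM;
compound 3, `CC(C)=CCC/C(C)=C/CC/C(C)=C/CSC[C@H](NC(=O)CCCCCN1CCN(C)CC1)C(=O)NC1CCCC1`.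

For compound 3 the read-out gives only a limit, > 20000 nM, not a number.

The change cyclohexyl in place of cyclopentyl on an amide-type nitrogen has been measured once: it made a 1.9-fold higher number from compound 2 to compound 1 (0.27 log units; within the scatter).

Compound 3 and compound 2 differ in their cores by 4-methylpiperazin-1-yl in place of pyrrolidin-1-yl on a saturated chain carbon, five bonds along the chain from a carbonyl carbon, a change that made an at least 2.9-fold higher number from compound 2 to compound 3 (0.46 log units; beyond the scatter), and compound 3 sits at the limit of > 20000 nM in this assay, at which 1 of the 3 values shown sits.

Compound 4, `CC(C)=CCC/C(C)=C/CC/C(C)=C/CSC[C@H](NC(=O)CCCCCN1CCN(C)CC1)C(=O)NC1CCCCC1`, has not been measured. It differs from compound 3 by cyclohexyl in place of cyclopentyl on an amide-type nitrogen, the same change as between compound 2 and compound 1. From compound 3 to compound 4 a step that the limit leaves unreadable from compound 3 to compound 4 is expected, resting on a 1.9-fold higher number from compound 2 to compound 1 (0.27 log units; within the scatter). Since compound 3 already sits at the limit, compound 4 is expected to give roughly 40000 nM, between 18000 nM and 120000 nM, most likely reported again only as a limit.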

Compound 4, half-maximal effective concentration: 12000 nM
Beside the measured number, compound 4's estimate is 3.3-fold (0.52 log units) above it; measured number outside the range, below it.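

In this assay, cyclohexyl in place of cyclopentyl on an amide-type nitrogen gave an at least 1.6-fold lower number from compound 3 to compound 4 (0.22 log units; that floor lies within the scatter), which does not repeat what the same change did on the core carrying pyrrolidin-1-yl: the same change on two cores in this assay, a 1.9-fold higher number (0.27 log units; within the scatter) from compound 2 to compound 1 and an at least 1.6-fold lower number (0.22 log units; that floor lies within the scatter) from compound 3 to compound 4, at least 3.1-fold (0.49 log units) apart, beyond the scatter of two such steps

Among the cyclohexyl compounds, 4-methylpiperazin-1-yl in place of pyrrolidin-1-yl gave a 1.1-fold lower number from compound 1 to compound 4 (0.02 log units; within the scatter), which also does not repeat its earlier result among the cyclopentyl compounds: the same change on two cores in this assay, an at least 2.9-fold higher number (0.46 log units; beyond the scatter) from compound 2 to compound 3 and a 1.1-fold lower number (0.02 log units; within the scatter) from compound 1 to compound 4, at least 3.1-fold (0.49 log units) apart, beyond the scatter of two such steps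

Among the compounds shown here, compound 3 gives > 20000 nM, a limit of the assay and not a number, so this shows only that neither change carried over unaltered between these two cores, not how large the true gap is or why it arises.

On these data alone, it remains open whether morpholin-4-yl or piperidin-1-yl in place of pyrrolidin-1-yl would respond to the cyclopentyl-to-cyclohexyl change as the pyrrolidin-1-yl pair does or as the 4-methylpiperazin-1-yl pair does. As far as these compounds go, a cycloheptyl group on the amide-type nitrogen is equally open.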